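Methoxy to hydroxy: solubility notes on two cores

This account rests on a few compounds, and the source may have more. Where it says the series, first, only, none or still open, it means among the compounds named here.

Compound 1 `COCCNC(=O)c1cnn(-c2cccc3cc(Cc4cccc(C(F)(F)F)c4)sc23)c1` and compound 2 `O=C(NCCO)c1cnn(-c2cccc3cc(Cc4cccc(C(F)(F)F)c4)sc23)c1` share one core; compound 3 `COCCNC(=O)c1c(C)nn(-c2cccc3cc(Cc4cccc(C(F)(F)F)c4)sc23)c1C` carries the same amide side chain as compound 1 on a second core, and the difference between the two cores is not broken down here. Compound 4 `Cc1nn(-c2cccc3cc(Cc4cccc(C(F)(F)F)c4)sc23)c(C)c1C(=O)NCCO` is the unmeasured partner of compound 3.

In a physicochemical assay for solubility, read by HPLC, at pH 6.8 (a lower number here means a less soluble compound, a higher number a more soluble compound), compound 1 gives only a limit, < 0.08 ug/mL. Compound 2 likewise gives only a limit, < 0.09 ug/mL. The change between them, (hydrogen in place of methyl on an oxygen on a saturated carbon), yields a step that the two limits leave unreadable from compound 1 to compound 2, and the step cannot be sized because the limit of < 0.08 ug/mL in this assay, at which 1 of the 3 values shown sits, and the limit of < 0.09 ug/mL in this assay, at which 1 of the 3 values shown sits, are both limits. In this assay, among the measured compounds shown here, compound 3 gives 2.9 ug/mL, the only number among the three.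

The change from compound 3 to compound 4, (hydrogen in place of methyl on an oxygen on a saturated carbon), is the same kind of change as that from compound 1 to compound 2, at the same place. Since the measured step is unreadable, no size is carried over from it; the expectation rests on compound 3 and its value 2.9 ug/mL alone. The step from compound 3 to compound 4 is expected to be small, a 1.2-fold higher number from compound 3 to compound 4 (0.08 log units; within the scatter). Compound 4 is estimated at 3.5 ug/mL, with a range from 1.2 ug/mL to 10 ug/mL.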

Compound 4, solubility: 12 ug/mL
The estimate for compound 4 lay 3.4-fold (0.54 log units) below the measured number; measured number above the stated range.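

On the second core, in this assay, the change from 2-methoxyethyl to 2-hydroxyethyl gives a 4.1-fold higher number from compound 3 to compound 4 (0.62 log units; beyond the scatter). The same change on the core of compound 1 and compound 2 stays unreadable, both compounds giving only limits of the assay, so nothing on that core confirms or contradicts this step. The series thus holds a single sized instance of the change: it shows what the change does on one core, and it does not show that a step of this size carries from one core to the other.

Open, as far as these compounds go, is whether the step on the second core holds for other chain ends, such as an amine or a carboxylic acid in place of the hydroxy, or for a longer chain ending in hydroxy. Also open, from the compounds shown here alone, is what the difference between the two cores contributes on its own, and whether a further core on which both partners give numbers would return a step of similar size.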